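Alpha-methyl on the amide chain of compound 2

A few compounds are considered here, and "the series" means these few. Any claim that something is new, unique, unknown or untested is made for them only; others in the source may bear on it.

Measured so far:
compound 1 `CC(C)C[C@H](N)c1cccnc1N1CCN(C(=O)CCc2ccc(Cl)cc2Cl)CC1` — 890 nM
compound 2 `CC(C)C[C@@H](N)c1cccnc1N1CCN(C(=O)CCc2ccc(Cl)cc2Cl)CC1` — 260 nM

In an assay on HEK293 cells for displacement of a labelled ligand from Melanocortin receptor 4 (Homo sapiens) (on this read-out lower numbers stand for stronger inhibition and higher numbers for weaker inhibition), compound 2 stands lowest of the two numbers. Going by the values given here, the only measured step is a 3.4-fold lower number from compound 1 to compound 2 (0.53 log units; beyond the scatter), a change of configuration alone (the fact that compounds 1 and 2 differ only in the configuration as drawn).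

Compound 3 `CC(C)C[C@@H](N)c1cccnc1N1CCN(C(=O)C(C)Cc2ccc(Cl)cc2Cl)CC1` differs from compound 2 by methyl in place of hydrogen on a saturated chain carbon bound to a carbonyl carbon and a saturated chain carbon. Among the compounds with values here, no measured step touches this chain carbon, so the configuration step gives no guide to it. A step within the scatter is expected, a 1.2-fold higher number from compound 2 to compound 3 (0.06 log units; within the scatter). Compound 3 is therefore estimated at 300 nM in this assay, with a range from 100 nM to 900 nM.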

Compound 3, inhibition constant: 36 nM
Compound 3: the middle estimate sits 8.3-fold (0.92 log units) above what was measured, outside the stated range (below it).
By their numbers in this assay, from the lowest: compound 3; then compound 2; then compound 1.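

In this assay the saturated chain carbon bound to a carbonyl carbon and a saturated chain carbon responds to substitution: methyl in place of hydrogen gives a 7.2-fold lower number from compound 2 to compound 3 (0.86 log units; beyond the scatter) and places compound 3 lowest of the three numbers. Going by these compounds alone, this is the first measured change away from the stereocentre of the earlier pair. Nothing at hand accounts for the step.

Going by these compounds, the new carbon is drawn without configuration in compound 3, so which form carries this number stays open. Also open, on these data alone, is how ethyl or a hydroxyl group would fare on this carbon.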